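This account rests on a few compounds, and the source may have more. Where it says the series, first, only, none or still open, it means among the compounds named here.

Measured compounds:
compound 1 `Cc1cc(Nc2cc(-c3ccc(Cl)cc3)[nH]n2)n2nc(SCc3ccc(Br)cc3)nc2n1` — 28200 nM
compound 2 `Cc1cc(Nc2cc(-c3ccccc3)[nH]n2)n2nc(SCc3ccccc3Br)nc2n1` — 41100 nM
compound 3 `Cc1ccc(Cn2ccc(Nc3cc(C)nc4nc(SCc5ccc(Br)cc5)nn34)n2)cc1` — > 50000 nM

In an ADME assay on GES1 cells (Homo sapiens) for inhibition, read by MTT assay, with a stated time of 72 h (a lower number here means a stronger inhibitor, a higher number a weaker inhibitor), compound 1 gives 28200 nM, and compound 2 gives 41100 nM, a gap that stays within the usual scatter, so the two cannot be told apart. For compound 3 the result of > 50000 nM is a limit of this assay, not a number; the limit of > 50000 nM in this assay, at which 1 of the 3 values shown sits, holds one of the three results. Compound 4 `Cc1cc(Nc2cc(C(C)(C)C)[nH]n2)n2nc(SCc3ccc(Br)cc3)nc2n1` has not been measured in this assay. It differs from compound 1 in one place: tert-butyl in place of 4-chlorophenyl on an aromatic carbon. Going by the values given here, no step between two measured compounds covers this change. Compound 4 is expected to sit near compound 1 in this assay, with an estimated step of a 1.2-fold higher number from compound 1 to compound 4 (0.09 log units; within the scatter) that stays within the scatter. The estimated value of compound 4 is 35000 nM, between 14000 nM and 80000 nM.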

Compound 4, half-maximal inhibitory concentration: > 50000 nM
Compound 4 gave a limit, no number; the forecaster's own chance of this, stated with the estimate: 30%; middle value at least 1.4-fold (0.15 log units) away from the limit.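

Swapping 4-chlorophenyl for tert-butyl on this aromatic carbon gives the first step at this position in this assay: an at least 1.7-fold higher number from compound 1 to compound 4 (0.24 log units; that floor lies within the scatter). That floor does not separate the two compounds, so the change shows no lower number, but no measured size of shift either. The result for compound 4 is a limit, not a number, and it is not alone there: the limit of > 50000 nM in this assay, at which 2 of the 4 values shown sit.

From the compounds shown here alone, how far compound 4 lies past that limit stays open. So does whether an amine or a carboxylic acid on this carbon would give a number inside the range of the assay.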